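Cytotoxicity of Nitroimidazole Sulfones: Chloro for Methyl

The source may report more compounds than this note shows. Statements on the series, on what has been measured and on what is new or still open speak of the compounds shown alone.

Measured compounds:
compound 1, `Cc1ccc(S(=O)(=O)Cc2ncn(C)c2[N+](=O)[O-])cc1`, > 846000 nM in an ADME assay on THP-1 cells (Homo sapiens) for cytotoxicity, read by flow cytometry and propidium iodide staining, with a stated time of 72 h; a lower number here means a stronger inhibitor, a higher number a weaker inhibitor
compound 2, `Cn1cnc(CS(=O)(=O)c2ccc(Cl)cc2)c1[N+](=O)[O-]`, 174000 nM
compound 3, `Cc1ccc(S(=O)(=O)Cc2nc(C)n(CC(C)O)c2[N+](=O)[O-])cc1`, > 707000 nM

For the measured compounds named here, in this series only one compound returned a number. Compound 1 stands at a limit of the assay, > 846000 nM, so no number is known for it (the limit of > 846000 nM in this assay, at which 1 of the 3 values shown sits). Compound 3 likewise sits at a limit, > 707000 nM, and gives no number either (the limit of > 707000 nM in this assay, at which 1 of the 3 values shown sits). Compound 2 alone was quantified, at 174000 nM.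

Going by the values given here, the one measured step is the exchange (chloro in place of methyl on an aromatic carbon), which produced an at least 4.8-fold lower number from compound 1 to compound 2 (0.68 log units; beyond the scatter). The cores of compound 1 and compound 3 differ in more than one place; the difference between the two cores is not broken down here.

The unmeasured compound 4, `Cc1nc(CS(=O)(=O)c2ccc(Cl)cc2)c([N+](=O)[O-])n1CC(C)O`, is made from compound 3 by the same kind of change, (chloro in place of methyl on an aromatic carbon). Since the step on compound 1 reached only a limit on one side, its true size is not fixed, and the core of compound 3 differs from that of compound 1 in several places, so the transfer is uncertain.

Compound 4 is therefore expected to land near 250000 nM, between 90000 nM and 800000 nM. This expectation means a step of about an at least 2.8-fold lower number from compound 3 to compound 4 (0.45 log units; beyond the scatter), resting on the change that moved compound 1 to compound 2 by an at least 4.8-fold lower number from compound 1 to compound 2 (0.68 log units; beyond the scatter).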

Compound 4, half-maximal inhibitory concentration: > 688000 nM
Compound 4 gave a limit, no number; the forecaster's own chance of this, stated with the estimate: 40%; at least 2.7-fold (0.43 log units) between middle value and limit.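

In this assay, compound 4 gives > 688000 nM, which is a limit and not a number. Compound 3 also gives a limit, > 707000 nM, so no step can be read between compound 3 and compound 4. The compounds shown leave open whether chloro in place of methyl changes the number at all on the core of compound 3.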